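The source may hold more compounds than are shown below. What is called first, only, known or untested is meant among the compounds shown, and "the series" means these compounds.

Of the compounds shown here, three have so far been tested in an ADME assay on L6 cells (Rattus norvegicus) for cytotoxicity, read by resazurin assay, with a stated time of 72 h; on this read-out lower numbers stand for stronger inhibition and higher numbers for weaker inhibition. Compound 1 `OC(c1ccc(Cl)cc1)(c1cncnc1)c1cccc(F)c1` gives only a limit, > 100000 nM, and not an exact number. Compound 2 `OC(c1ccc(Cl)cc1)(c1cccnc1)c1ccccc1F` also gives only a limit, > 100000 nM. Compound 3 `OC(c1ccc(Cl)cc1)(c1cnccn1)c1ccccc1Cl` likewise gives only a limit, > 100000 nM, so it has no exact position on the scale. All the data so far come down to the limit of > 100000 nM in this assay, at which 3 of the 3 values shown sit.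

Compound 4 `OC(c1ccc(Cl)cc1)(c1ccncn1)c1ccccc1Cl` has the same atoms as compound 3, joined differently, with pyrimidin-4-yl in place of pyrazin-2-yl on a saturated chain carbon bound to two aromatic carbons and an oxygen on a saturated carbon. Among the measured compounds shown here, no two measured compounds differ in only one place, so no measured step can serve as a guide. No change beyond the usual scatter is therefore expected in this assay, and another limit is the likeliest report. The expected step runs a number no higher from compound 3 to compound 4 (the limit leaves the size open). For compound 4 the estimated value is 100000 nM, with an expected range from 40000 nM to 150000 nM.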

Compound 4, half-maximal inhibitory concentration: > 100000 nM
Compound 4: a limit, no number; the forecaster's own chance of this, stated with the estimate: 75%; the middle value lies on the limit itself.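

Compound 3 and compound 4 both give only limits and not numbers, so the step between them, pyrimidin-4-yl in place of pyrazin-2-yl, cannot be read. The compounds shown leave open what exact value, if any, any of them would reach in this assay.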